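The source may hold more compounds than are shown below. What is called first, only, known or untested is meant among the compounds shown, and "the series" means these compounds.

Measured compounds in a functional assay on HT-29 cells (Homo sapiens) for cytotoxicity, read by sulforhodamine B assay, with a stated time of 2 days, tested at 100 uM; a lower number here means less inhibition, a higher number more inhibition at the concentration tested (going by the name of the read-out):

compound 1 `O=C(Nn1c(-c2cccc([N+](=O)[O-])c2)nc2c(-c3ccc(Cl)cc3)n[nH]c2c1=O)c1cccnc1` gives 15.1%
compound 2 `O=C(Nn1c(-c2cccc([N+](=O)[O-])c2)nc2c(-c3ccc(Cl)cc3)n[nH]c2c1=O)c1ccccc1` gives 87.8%
compound 3 `O=C(Nn1c(-c2cccc([N+](=O)[O-])c2)nc2c(-c3ccco3)n[nH]c2c1=O)c1ccccc1` gives 21.2%

Compound 2 holds the highest number of the three, with the steps to compound 3 and to compound 1 both beyond the scatter. The two single-place steps recorded so far are both large: a number 72.7 percentage points higher from compound 1 to compound 2 (beyond the scatter) and a number 66.6 percentage points lower from compound 2 to compound 3 (beyond the scatter). Each of them alters one of the two aryl arms of the shared core, and each moves the read-out by a wide margin.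

Compound 4 `O=C(Nn1c(CCc2ccccc2)nc2c(-c3ccc(Cl)cc3)n[nH]c2c1=O)c1ccccc1` differs from compound 2 at a third place: phenethyl in place of 3-nitrophenyl on an aromatic carbon. The group sits on an aromatic carbon of the core, between two ring nitrogen atoms and ortho to the benzamido group. Going by the values given here, no measured step touches this position, so neither recorded step bears on it directly; what they show is only that single changes on this core have produced large moves in this assay, and that both changes away from compound 2 so far have lowered the number. A large step in either direction is therefore possible for compound 4, with a downward move somewhat more likely on the present numbers. Compound 4 is expected to give 45% in this assay, within 10% to 88%. The expected step is a number 42.8 percentage points lower from compound 2 to compound 4 (beyond the scatter).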

Compound 4, a percentage reported as inhibition, at one concentration (the size of the read-out at that concentration, not a potency): 86.5%
Compound 4: the middle estimate sits 41.5 percentage points below what was measured; measured number inside the range.
By their numbers in this assay, from the lowest: compounds 1 and 3 (each within the scatter of the next); then compounds 4 and 2 (each within the scatter of the next).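

At the aromatic carbon between two ring nitrogen atoms, phenethyl in place of 3-nitrophenyl gives a number 1.3 percentage points lower from compound 2 to compound 4 (within the scatter) in this assay. Going by these compounds alone, this is the first single change on the shared core that does not separate two compounds in this read-out, so a large move is not a general outcome of changing one place. Neither the nitrogen and oxygen atoms of 3-nitrophenyl nor an aromatic ring attached directly at this carbon is needed to keep the number of compound 4 level with that of compound 2, and nothing shown accounts for this result.

Open, as far as these compounds go, is whether an amine, a carboxylic acid or a longer chain such as 3-phenylpropyl at this carbon would hold the number as well. A read-out at one concentration also leaves open whether compound 2 and compound 4 differ in potency.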